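A methylphenyl group in place of difluorophenyl

The compounds below may be only part of what the source reports. "The series", "measured", "known", "first", "only" and "open" are said of these compounds alone.

Going by the values given here, compound 2 `O=C(Nc1ccccc1Br)N[C@@H]1CCN(c2ccc(F)c(F)c2)C1` is the stronger of the two compounds measured so far in a functional assay for antagonist activity at transient receptor potential cation channel subfamily V member 1 (Rattus norvegicus), read by FLIPR; on this read-out lower numbers stand for lower potency and higher numbers for higher potency (the scale is a negative logarithm). In this assay compound 2 gives 8.1, while compound 1 `N#Cc1ccc(N2CC[C@@H](NC(=O)Nc3ccccc3Br)C2)nc1` gives 6.7. Among the compounds with values here, the only change between them sits on the amine nitrogen in the ring, and the step of a number 1.40 log units higher from compound 1 to compound 2 (beyond the scatter) shows how much that position can matter.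

Compound 3 `Cc1cccc(N2CC[C@@H](NC(=O)Nc3ccccc3Br)C2)c1` differs from compound 2 at the same position: 3-methylphenyl in place of 3,4-difluorophenyl on an amine nitrogen in a ring. Within the data shown here, no measured step covers this particular exchange. Among the measured compounds shown here, the one measured step, from compound 1 to compound 2, concerns a different pair of groups on this nitrogen, and its size is only a sign that the position is sensitive. Nothing shows in which direction a methylphenyl group moves the number. For compound 3 the expected change is a number 0.30 log units lower from compound 2 to compound 3 (within the scatter), which may stay within the scatter or fall a little. The estimate for compound 3 in this assay is 7.8, with a range from 7 to 8.5.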

Compound 3, negative logarithm of the antagonist equilibrium constant in the transient receptor potential cation channel subfamily V member 1 assay: 7.7
Compound 3: middle estimate off by 0.10 log units, on the high side; low and high end bracket the measured number.
By their numbers in the transient receptor potential cation channel subfamily V member 1 assay, from the lowest: compound 1; then compound 3; then compound 2.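

In the transient receptor potential cation channel subfamily V member 1 assay, 3-methylphenyl in place of 3,4-difluorophenyl on the amine nitrogen in the ring gives a number 0.40 log units lower from compound 2 to compound 3 (beyond the scatter), so this exchange between two carbon-only aromatic rings moves the number far less than the step from 5-cyanopyridin-2-yl to 3,4-difluorophenyl did. 3-Methylphenyl in place of 5-cyanopyridin-2-yl gives a number 1.00 log units higher from compound 1 to compound 3 (beyond the scatter), which means that both compounds with a carbon-only aromatic ring on this nitrogen now stand clear of compound 1, and a group without fluorine can do this as well. In a physicochemical assay for solubility (a higher number here means a more soluble compound, a lower number a less soluble compound), compound 2 gives < 100 ug/mL as a limit of the assay and not as a number. In the physicochemical assay compound 3 gives < 100 ug/mL as a limit of the assay and not as a number. In the physicochemical assay, the step cannot be read, because compound 2 and compound 3 both sit at a limit of the assay and not at a number: the limit of < 100 ug/mL in the physicochemical assay, at which 2 of the 2 values shown sit.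

On these data alone, one exchange cannot separate the effect of the fluorine atoms from that of the methyl group, and it remains open how a plain phenyl, a 3-chlorophenyl or a 3-methoxyphenyl group would compare on this nitrogen. As far as these compounds go, it is also open whether a group such as a morpholine or a carboxylic acid on the aromatic ring would bring a compound clear of that limit in the physicochemical assay while holding its number in the transient receptor potential cation channel subfamily V member 1 assay.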